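Swapping methyl for cyano on the amide-bearing ring

The source may report more compounds than this note shows. Statements on the series, on what has been measured and on what is new or still open speak of the compounds shown alone.

Compound 1 `Cc1ccc(NC(=O)C2CCN(C/C=C/c3ccccc3)CC2)cc1` is the weakest of three measured compounds in a functional assay on A549 cells (Homo sapiens) for inhibition, read by MTT assay, with a stated time of 72 h (on this read-out higher numbers stand for weaker inhibition and lower numbers for stronger inhibition), where compound 1 gives 29600 nM. Compound 2 `CC(C)c1ccc(NC(=O)C2CCN(C/C=C/c3ccccc3)CC2)cc1` gives 9430 nM, and compound 3 `CCCCCc1ccc(NC(=O)C2CCN(C/C=C/c3ccccc3)CC2)cc1` gives 3880 nM. Both steps away from compound 1 lowered the number: a 3.1-fold lower number from compound 1 to compound 2 (0.50 log units; beyond the scatter) and a 7.6-fold lower number from compound 1 to compound 3 (0.88 log units; beyond the scatter), with a 2.4-fold lower number from compound 2 to compound 3 (0.39 log units; beyond the scatter) between the other two. Compound 4 `N#Cc1ccc(NC(=O)C2CCN(C/C=C/c3ccccc3)CC2)cc1` differs from compound 1 by cyano in place of methyl on an aromatic carbon. Among the measured compounds shown here, none of the measured steps bears on this change directly: each of them replaced one alkyl group with a larger alkyl group, whereas here a cyano group replaces methyl and brings one hydrogen-bond acceptor. The measured steps therefore give no firm direction, and the expectation for compound 4 is a number close to that of compound 1, with wide uncertainty on either side. Compound 4 is estimated at 25000 nM, between 8000 nM and 80000 nM, which would be a step of a 1.2-fold lower number from compound 1 to compound 4 (0.07 log units; within the scatter) expected from compound 1.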

Compound 4, half-maximal inhibitory concentration: 40200 nM
Estimate against measurement, compound 4: 1.6-fold (0.21 log units) below; low and high end bracket the measured number.
By their numbers in this assay, from the lowest: compound 3; then compound 2; then compounds 1 and 4 (each within the scatter of the next).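

In this assay, among the compounds shown here, cyano is the first group at this position that is not an alkyl group, and exchanging it for methyl leaves the number within the scatter (a 1.4-fold higher number from compound 1 to compound 4 (0.13 log units; within the scatter)). The larger alkyl groups stand clearly apart from cyano (a 4.3-fold higher number from compound 2 to compound 4 (0.63 log units; beyond the scatter); a 10-fold higher number from compound 3 to compound 4 (1.02 log units; beyond the scatter)). Among these four compounds, the lower numbers therefore belong to isopropyl and pentyl, while methyl and cyano cannot be told apart, and nothing available explains this result.

Still open, from the compounds shown here alone, is whether the number keeps falling with a chain longer than pentyl. Going by these compounds, it is equally open whether an amine or a carboxylic acid at this position would read like cyano or like the larger alkyl groups.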